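The source may report more compounds than this note shows. Statements on the series, on what has been measured and on what is new or still open speak of the compounds shown alone.

Measured so far:
compound 1 `O=C(Nc1cccc(-n2cc(-c3ccncc3)c(-c3ccc(Cl)c(O)c3)n2)c1)Nc1cccc(C(F)(F)F)c1`: > 32500 nM
compound 2 `COc1cc(-c2nn(-c3cccc(NC(=O)Nc4cc(C(F)(F)F)cc(C(F)(F)F)c4)c3)cc2-c2ccncc2)ccc1Cl`: 3680 nM
compound 3 `COc1cc(-c2nn(-c3cccc(NC(=O)Nc4cccc(C(F)(F)F)c4)c3)cc2-c2ccncc2)ccc1Cl`: 12500 nM

In a functional assay on Hs-578T cells (Homo sapiens) for inhibition, read by sulforhodamine B assay, with a stated time of 48 h (a lower number here means a stronger inhibitor of growth, a higher number a weaker inhibitor of growth), compound 1 reaches only (the limit of > 32500 nM in this assay, at which 1 of the 3 values shown sits), which is a limit and not a number. Among the two numbers shown, compound 3 has the higher one; its nearest neighbour is seen in a 3.4-fold higher number from compound 2 to compound 3 (0.53 log units; beyond the scatter). Compound 4 `COc1cc(-c2nn(-c3cccc(NC(=O)c4ccccc4)c3)cc2-c2ccncc2)ccc1Cl` differs from compound 3 by phenyl in place of (3-(trifluoromethyl)phenyl)amino on a carbonyl carbon. The measured step that bears on this is a 3.4-fold higher number from compound 2 to compound 3 (0.53 log units; beyond the scatter), where removing a trifluoromethyl from that ring already weakened growth inhibition; here the whole ring with its trifluoromethyl and its amide hydrogen goes. A further rise beyond the scatter is therefore expected, a 2.4-fold higher number from compound 3 to compound 4 (0.38 log units; beyond the scatter). Compound 4 is estimated at 30000 nM, expected to fall between 8000 nM and 100000 nM.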

Compound 4, concentration for total growth inhibition: > 100000 nM
Compound 4: only a limit was reported (the forecaster's own chance of this, stated with the estimate: 45%); middle value at least 3.3-fold (0.52 log units) from the limit.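

In this assay compound 4 gives > 100000 nM, which is a limit and not a number. The step reads an at least 8.0-fold higher number from compound 3 to compound 4 (0.90 log units; beyond the scatter), so phenyl on this carbonyl carbon gives clearly weaker growth inhibition than (3-(trifluoromethyl)phenyl)amino. The earlier steps shown here changed only a trifluoromethyl or a methyl on oxygen, whereas this one replaces the whole group on the carbonyl carbon.

This single change removes the amine nitrogen and the trifluoromethyl together, so the compounds shown cannot separate their contributions. From the compounds shown here alone, whether a plain phenylamino group or a piperidine on this carbonyl carbon would restore growth inhibition remains open.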